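Replacing a Piperidine Chain with Benzyl on the Shared Core

The compounds below may be only part of what the source reports. "The series", "measured", "known", "first", "only" and "open" are said of these compounds alone.

Compound 1, `N#Cc1ccc(Cn2c(=O)n(C3OC(CO)[C@@H](O)[C@H]3O)c3nc(N)nc(O)c32)cc1`, gives 50% in a functional assay on the whole organism (B cells) with Mus musculus as the target; on this read-out higher numbers stand for larger maximal responses and lower numbers for smaller maximal responses.
Compound 2, `Nc1nc(O)c2c(n1)n(C1OC(CO)[C@@H](O)[C@H]1O)c(=O)n2CCN1CCCCC1`, gives 0% in this assay.

Within the data shown here, of the two measured compounds, compound 2 stands lowest, and its only neighbour is compound 1: a number 50 percentage points lower from compound 1 to compound 2 (beyond the scatter). In that step an aromatic ring on the saturated chain carbon bound to an aromatic nitrogen gave way to (piperidin-1-yl)methyl, and the maximal response fell by a large amount.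

Compound 3, `Nc1nc(O)c2c(n1)n(C1OC(CO)[C@@H](O)[C@H]1O)c(=O)n2Cc1ccccc1`, has not yet been measured. It differs from compound 2 in one place: phenyl in place of (piperidin-1-yl)methyl on a saturated chain carbon bound to an aromatic nitrogen. Among the measured compounds shown here, this reverses the direction of the single step known so far, bringing an aromatic ring back onto that chain carbon. A rise beyond the scatter is therefore expected, though the phenyl of compound 3 lacks the nitrile of compound 1, so the full recovery is uncertain.

Compound 3 is estimated to reach 40%, with a range from 10% to 70%. That estimate means an expected step of a number 40 percentage points higher from compound 2 to compound 3 (beyond the scatter).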

Compound 3, largest response reached (reported as maximal response), in percent of the reference or control that the assay uses: 110%
Compound 3: middle estimate off by 70 percentage points, on the low side; measured number above the stated range.
By their numbers in this assay, from the lowest: compound 2; then compound 1; then compound 3.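

In this assay, phenyl in place of (piperidin-1-yl)methyl gives a number 110 percentage points higher from compound 2 to compound 3 (beyond the scatter), so the response at this position does more than return to the level of compound 1. The nitrile is not needed for that response: hydrogen in place of cyano on an aromatic carbon gives a number 60 percentage points higher from compound 1 to compound 3 (beyond the scatter), and the simpler benzyl group stands highest of the three. Nothing measured here explains either step.

Still open, going by these compounds, is whether the aromatic ring itself or the loss of the piperidine ring accounts for the rise, a question that cyclohexylmethyl on the same aromatic nitrogen could help settle. On these data alone, it is also open whether methoxy or chlorine on that aromatic carbon would behave like hydrogen or like cyano.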